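This account rests on a few compounds, and the source may have more. Where it says the series, first, only, none or still open, it means among the compounds named here.

Compound 1 `COc1cc(OC)c2c(=O)c(OCC(=O)N/N=C/c3ccc[nH]3)c(-c3cc(OC)c(OC)c(OC)c3)oc2c1` is the reference of this set. In a functional assay on MDA-MB-231 cells (Homo sapiens) for cytotoxicity, read by MTT assay, with a stated time of 38 h (on this read-out lower numbers stand for stronger inhibition and higher numbers for weaker inhibition), compound 1 gives 3750 nM, the second highest of the three numbers; compound 2 `COc1cc(OC)c2c(=O)c(OCCCCN3CCCCC3)c(-c3cc(OC)c(OC)c(OC)c3)oc2c1` gives 3030 nM and compound 3 `COc1cc(OC)c2c(=O)c(OCCCCN3CCN(C)CC3)c(-c3cc(OC)c(OC)c(OC)c3)oc2c1` gives 3870 nM. Compound 4 `COc1cc(OC)c2c(=O)c(OCCCN3CCN(C)CC3)c(-c3cc(OC)c(OC)c(OC)c3)oc2c1` is not yet measured; it differs from compound 1 by a group of 9 heavy atoms (7 carbon, 2 nitrogen; one six-membered non-aromatic ring with 2 hetero atoms) in place of a group of 10 heavy atoms (6 carbon, 3 nitrogen, 1 oxygen; one five-membered aromatic ring with 1 hetero atom), on a saturated chain carbon bound to an oxygen on an aromatic ring. Within the data shown here, the steps that bear on this change are a 1.2-fold lower number from compound 1 to compound 2 (0.09 log units; within the scatter) and a 1.0-fold higher number from compound 1 to compound 3 (0.01 log units; within the scatter), both replacing the same group with a chain carrying a saturated nitrogen ring, and a 1.3-fold higher number from compound 2 to compound 3 (0.11 log units; within the scatter). Among the measured compounds shown here, no measured step here leaves the scatter, so for compound 4 no step beyond the scatter is expected: a 1.0-fold higher number from compound 1 to compound 4 (0.01 log units; within the scatter). The estimate for compound 4 is 3800 nM, within 2000 nM to 7500 nM.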

Compound 4, half-maximal inhibitory concentration: 30100 nM
The estimate for compound 4 lay 7.9-fold (0.90 log units) below the measured number, and the stated range ends below it.
By their numbers in this assay, from the lowest: compounds 2, 1 and 3 (each within the scatter of the next); then compound 4.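

In this assay, among these compounds, the 2-(4-methylpiperazin-1-yl)ethyl group, on a saturated chain carbon bound to an oxygen on an aromatic ring, gives the first step beyond the scatter: an 8.0-fold higher number from compound 1 to compound 4 (0.90 log units; beyond the scatter). With the 4-methylpiperazin-1-yl ring kept, the shorter chain alone gives a 7.8-fold higher number from compound 3 to compound 4 (0.89 log units; beyond the scatter) and the step from the piperidin-1-yl chain is of similar size, a 9.9-fold higher number from compound 2 to compound 4 (1.00 log units; beyond the scatter), so at this position chain length counts where the ring exchange stayed within the scatter. Nothing at hand gives a reason for this loss.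

Open, on these data alone, is whether piperidin-1-yl on the shorter chain loses as much, and how a longer chain or a morpholine ring would read.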